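Aryl Change at the Saturated Ring Carbon: Compound 4

The source may report more compounds than this note shows. Statements on the series, on what has been measured and on what is new or still open speak of the compounds shown alone.

Compound 1 `N#CC1=C(N)N(c2ccc(S(N)(=O)=O)cc2)C2=C(C(=O)CCC2)C1c1ccccc1` gives 10% in a functional assay on Ehrlich cells (Mus musculus) for antiproliferative activity, read by trypan blue exclusion, with a stated time of 2 h, tested at 10 ug/mL; a lower number here means a weaker effect, a higher number a stronger effect of the compound at the concentration tested.
Compound 2 `Cc1ccc(C2C(C#N)=C(N)N(c3ccc(S(N)(=O)=O)cc3)C3=C2C(=O)CCC3)cc1` gives 30% in this assay.
Compound 3 `N#CC1=C(N)N(c2ccc(S(N)(=O)=O)cc2)C2=C(C(=O)CCC2)C1c1ccc(Cl)cc1Cl` gives 40% in this assay.

Compound 2 stands second highest of the three values. Its nearest neighbour is reached by a number 10 percentage points higher from compound 2 to compound 3 (within the scatter), and the furthest by a number 20 percentage points higher from compound 1 to compound 2 (beyond the scatter), so compound 2 is clearly separated from one measured compound and not from the other.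

Compound 4 `COc1ccc2ccccc2c1C1C(C#N)=C(N)N(c2ccc(S(N)(=O)=O)cc2)C2=C1C(=O)CCC2` has not yet been measured in this assay. It differs from compound 2 by 2-methoxynaphthalen-1-yl in place of 4-methylphenyl on a saturated ring carbon. Two measured steps change the group at that same saturated ring carbon: a number 30 percentage points higher from compound 1 to compound 3 (beyond the scatter), a modest rise, and a number 10 percentage points higher from compound 2 to compound 3 (within the scatter), which stays within the scatter. Neither of them brings in a methoxy group or a second aromatic ring, so the data give only a direction, not a size: a small rise or no change beyond the scatter is the expectation for compound 4 in this assay. On that basis compound 4 is estimated to give 40%, with a range from 20% to 60%. This estimate means that a number 10 percentage points higher from compound 2 to compound 4 (within the scatter) is expected.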

Compound 4, a percentage reported as activity, at one concentration (the size of the read-out at that concentration, not a potency): 40%
The estimate for compound 4 equals the measured number at the digits printed, and the stated range covers the measured number.
By their numbers in this assay, from the lowest: compound 1; then compounds 2, 3 and 4 (each within the scatter of the next).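

In this assay the saturated ring carbon accepts the much larger 2-methoxynaphthalen-1-yl, with its two six-membered aromatic rings of carbon only and its hydrogen-bond acceptor, with no fall beyond the scatter: the exchange for 4-methylphenyl gives a number 10 percentage points higher from compound 2 to compound 4 (within the scatter) and the exchange for 2,4-dichlorophenyl gives no change at the digits printed from compound 3 to compound 4 (within the scatter) as the reading. Set against plain phenyl, the same group gives a number 30 percentage points higher from compound 1 to compound 4 (beyond the scatter) as its step, so compound 4 joins compound 2 and compound 3 in a group whose members all lie within the scatter of one another, with compound 1 alone lying apart from all three. Nothing measured here accounts for these numbers or shows what the three substituted aryl groups share that plain phenyl lacks.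

Going by these compounds, whether the methoxy group or the second aromatic ring contributes more to the value of compound 4 remains open, since the two enter together in a single step. Also open, on these data alone, is what a carboxylic acid or a dimethylamino group on the aryl ring, or a cyclohexyl group in place of the aryl ring at this carbon, would give in this assay at this one concentration.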